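The source may report more compounds than this note shows. Statements on the series, on what has been measured and on what is new or still open speak of the compounds shown alone.

Working notes on the series. In an ADME assay on NHDF cells (Homo sapiens) for antiproliferative activity, with a stated time of 72 h (on this read-out higher numbers stand for weaker inhibition and lower numbers for stronger inhibition), compound 3 `COc1ccccc1/C=C/c1nc(Nc2cccc(O)c2)c2ccccc2n1` gives 17500 nM and compound 2 `COc1ccccc1/C=C/c1nc(Nc2ccc(O)cc2)c2ccccc2n1` gives 13800 nM. These two values stand level, with a 1.3-fold higher number from compound 2 to compound 3 (0.10 log units; within the scatter). Compound 1 `COc1ccccc1/C=C/c1nc(Nc2ccccc2Cl)c2ccccc2n1` gives only a limit, > 25000 nM, and not a number. Two steps start from that limit, an at least 1.8-fold lower number from compound 1 to compound 2 (0.25 log units; that floor lies within the scatter) and an at least 1.4-fold lower number from compound 1 to compound 3 (0.15 log units; that floor lies within the scatter).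

The change to compound 4 `COc1ccc(/C=C/c2nc(Nc3cccc(O)c3)c3ccccc3n2)cc1` is 4-methoxyphenyl in place of 2-methoxyphenyl on a double-bonded chain carbon bound to a double-bonded chain carbon, with 4-methoxyphenyl in place of 2-methoxyphenyl on a double-bonded chain carbon bound to a double-bonded chain carbon.

Among the measured compounds shown here, no measured step changes this group. All three measured steps concern the group on a nitrogen on an aromatic ring. The closest parallel is the swap of 4-hydroxyphenyl for 3-hydroxyphenyl, a 1.3-fold higher number from compound 2 to compound 3 (0.10 log units; within the scatter), so it offers only indirect support. On that basis, no change beyond the scatter is expected in this assay, and a limit reading remains possible.

The expected step is a 1.1-fold lower number from compound 3 to compound 4 (0.04 log units; within the scatter).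

Compound 4 is estimated at 16000 nM, with an expected range of 7000 nM to 25000 nM.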

Compound 4, half-maximal inhibitory concentration: > 25000 nM
Compound 4: no number, only a limit (the forecaster's own chance of this, stated with the estimate: 25%); at least 1.5-fold (0.19 log units) between middle value and limit.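

Moving the methoxy group, with 4-methoxyphenyl in place of 2-methoxyphenyl, gives an at least 1.4-fold higher number from compound 3 to compound 4 (0.15 log units; that floor lies within the scatter), so the first step at this place on a double-bonded chain carbon has only a floor, and that floor does not separate the pair. In this assay, compound 4 gives a limit and not a number, and this change brings no lower number. Two of the compounds now sit at the limit, one differing in the group on the nitrogen and the other in the methoxyphenyl group, so neither change can be sized in full: the limit of > 25000 nM in this assay, at which 2 of the 4 values shown sit.

As far as these compounds go, how far compound 4 lies past its limit stays open, as does whether the change would act alike with 4-hydroxyphenyl on the nitrogen. From the compounds shown here alone, it is also open whether a plain phenyl, or a phenyl carrying an amine, at this place would give a number within range.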